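Methyl for Nitro on a Thiazolylidene Hydrazide Core

The source may report more compounds than this note shows. Statements on the series, on what has been measured and on what is new or still open speak of the compounds shown alone.

The account follows cytotoxicity in an ADME assay on NIH3T3 cells (Mus musculus) for cytotoxicity, read by MTT assay, with a stated time of 24 h; on this read-out higher numbers stand for weaker inhibition and lower numbers for stronger inhibition. Among the compounds with values here, compound 2, `Cn1cnnc1SCC(=O)N/N=c1/scc(-c2ccc([N+](=O)[O-])cc2)n1-c1ccccc1`, gives 133 ug/mL in this assay, and this is the only actual number among the two values shown. The other value is the limit of > 500 ug/mL in this assay, at which 1 of the 2 values shown sits. Compound 1, `Cc1ccc(-c2cs/c(=N/NC(=O)CSc3nnnn3-c3ccccc3)n2-c2ccccc2)cc1`, reaches only that limit of this assay, > 500 ug/mL, so no number is known for it. Compound 3, `Cc1ccc(-c2cs/c(=N/NC(=O)CSc3nncn3C)n2-c2ccccc2)cc1`, is not yet measured; it differs from compound 2 by methyl in place of nitro on an aromatic carbon, para to a large group, so that 4-nitrophenyl becomes 4-methylphenyl. Within the data shown here, no measured pair shows this change directly, so the step has to be expected rather than read off. The author expects the step of a 2.3-fold higher number from compound 2 to compound 3 (0.35 log units; beyond the scatter) to go toward weaker inhibition, probably somewhat beyond the usual scatter, though the uncertainty is wide and a limit rather than a number is a real possibility. Compound 3 is therefore estimated at 300 ug/mL in this assay, with a range from 120 ug/mL to 600 ug/mL.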

Compound 3, half-maximal inhibitory concentration: 130 ug/mL
Compound 3: the middle estimate sits 2.3-fold (0.36 log units) above what was measured; the measured number falls inside the stated range.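

In this assay, methyl in place of nitro on an aromatic carbon, para to a large group, gives a 1.0-fold lower number from compound 2 to compound 3 (0.01 log units; within the scatter), so 4-nitrophenyl and 4-methylphenyl cannot be told apart on this read-out. The change on the sulfur does register: 4-methyl-4H-1,2,4-triazol-3-yl in place of 1-phenyl-1H-tetrazol-5-yl gives an at least 3.8-fold lower number from compound 1 to compound 3 (0.58 log units; beyond the scatter), which places the visible difference in this series at the sulfur substituent and not at the para position of the phenyl ring. Compound 1 stands at a limit and not at a number, so that step is only a bound on the true size of the change: the limit of > 500 ug/mL in this assay, at which 1 of the 3 values shown sits.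

The compounds shown leave open whether a different group at the same aromatic carbon, such as an amine or a carboxylic acid, would move the number beyond the scatter, as only nitro and methyl stand there so far. They also leave open whether the step on the sulfur keeps its size with 4-nitrophenyl on the core, and what a longer chain in place of either ring on the sulfur would do.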